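Amines and a Thiol on a Shared Nucleoside Core

The source may report more compounds than this note shows. Statements on the series, on what has been measured and on what is new or still open speak of the compounds shown alone.

Compound 1 `OC[C@H]1OC(n2cnc3c(Nc4ccccc4)nccc32)[C@H](O)[C@@H]1O`, compound 2 `CCNc1nccc2c1ncn2C1O[C@H](CO)[C@@H](O)[C@H]1O` and compound 3 `OC[C@H]1OC(n2cnc3c(S)nccc32)[C@H](O)[C@@H]1O` share one core and differ only in the group on an aromatic carbon. In a functional assay (Homo sapiens) for inhibition of Nucleic Acid, tested at 100 uM (a higher number here means more inhibition at the concentration tested (going by the name of the read-out), a lower number less inhibition), compound 3 gives 6%, which sits within the scatter of the others: compound 1 gives 4% and compound 2 gives 4%. The step of a number 2 percentage points higher from compound 1 to compound 3 (within the scatter) and the step of a number 2 percentage points higher from compound 2 to compound 3 (within the scatter) both fall within the scatter, as does no change at the digits printed from compound 1 to compound 2 (within the scatter).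

Compound 4 `CN(C)c1nccc2c1ncn2C1O[C@H](CO)[C@@H](O)[C@H]1O` carries dimethylamino in place of sulfanyl on an aromatic carbon. Since both measured exchanges at this carbon, to and from an amino group, left the read-out essentially unchanged, no movement beyond the scatter is expected, and compound 4 is estimated at 5% (range -4% to 14%), a step of a number 1 percentage points lower from compound 3 to compound 4 (within the scatter).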

Compound 4, a percentage reported as inhibition, at one concentration (the size of the read-out at that concentration, not a potency): 0%
For compound 4 the middle estimate is 5 percentage points above the measured one, within the range that was stated.
By their numbers in this assay, from the lowest: compounds 4, 1, 2 and 3 (each within the scatter of the next).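

In this assay the step of a number 6 percentage points lower from compound 3 to compound 4 (within the scatter) and the step of a number 4 percentage points lower from compound 2 to compound 4 (within the scatter) and also the step of a number 4 percentage points lower from compound 1 to compound 4 (within the scatter) leave all four compounds within the scatter of one another. On this aromatic carbon, next to the ring nitrogen, dimethylamino with its 0 hydrogen-bond donors thus reads no differently from sulfanyl with its 1 hydrogen-bond donor, and no differently from the two amines with one substituent on nitrogen. Nothing measured here speaks to why the numbers stay so close.

Going by these compounds, whether a carboxylic acid or a longer alkyl chain on this carbon would move the read-out beyond the scatter remains open. So does the effect of any change elsewhere on the shared core, such as on the sugar hydroxyl groups.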